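The source may report more compounds than this note shows. Statements on the series, on what has been measured and on what is new or still open speak of the compounds shown alone.

Working notes on the series. Compound 1 `O=C(N/N=C/c1ccccc1)c1cnccn1` and compound 2 `CC(C)c1ccc(/C=N/NC(=O)c2cnccn2)cc1` share the same core; in a functional assay on the whole organism (strain Swiss) for inhibition, with Mus musculus as the target, read by paw edema, with stated times of 40 min and 30 min, at a dose of 100 umol/kg by the oral route (on this read-out lower numbers stand for less inhibition and higher numbers for more inhibition at the one dose given (going by the name of the read-out)), compound 1 gives 30.5%, and in this assay compound 2 gives 46.6%. Within the data shown here, compound 2 holds the higher of the two numbers measured so far, its nearest neighbour being compound 1, separated by the step of a number 16.1 percentage points higher from compound 1 to compound 2 (beyond the scatter). Compound 3 `O=C(N/N=C/c1ccc(F)cc1)c1cnccn1` has not yet been measured in this assay. It differs from compound 2 by fluoro in place of isopropyl on an aromatic carbon, on an aromatic carbon of a six-membered aromatic ring of carbon only, para to a large group. Among the measured compounds shown here, only one measured step bears on this change, a number 16.1 percentage points higher from compound 1 to compound 2 (beyond the scatter), which put isopropyl in place of hydrogen at the same position and raised the number modestly. The present change takes that isopropyl away again and puts in fluoro, so a move back towards the number of compound 1 is the natural expectation, though fluoro is not hydrogen and the size is uncertain. The step is therefore expected to be downward, estimated as a number 10.6 percentage points lower from compound 2 to compound 3 (beyond the scatter), and may not clear the scatter. Compound 3 is expected to give about 36% in this assay, with a range of 24% to 50%.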

Compound 3, a percentage reported as inhibition, in the whole organism at one dose (the size of the read-out at that dose, not a potency): 33.1%
Beside the measured number, compound 3's estimate is 2.9 percentage points above it, within the range that was stated.
By their numbers in this assay, from the lowest: compounds 1 and 3 (each within the scatter of the next); then compound 2.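

In this assay, fluoro in place of isopropyl on this aromatic carbon gives a number 13.5 percentage points lower from compound 2 to compound 3 (beyond the scatter), so the gain seen with isopropyl does not carry over to fluoro. Fluoro in place of hydrogen gives a number 2.6 percentage points higher from compound 1 to compound 3 (within the scatter), which means that at this place, para to a large group, the two cannot be told apart on this read-out, and of the three compounds only compound 2 stands apart from the others, with its steps to both beyond the scatter. Nothing available on these compounds gives a reason for this difference between isopropyl and the two smaller substituents.

On these data alone, whether the rise is particular to isopropyl, or also comes with a tert-butyl, methoxy or dimethylamino group on the same aromatic carbon, remains open. As far as these compounds go, the read-out gives the size of the effect at one dose and not a potency, so it also remains open whether compound 2 would keep its lead at other doses.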